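A Methyl Added to the Better Tolerated Compound 2

The compounds below may be only part of what the source reports. "The series", "measured", "known", "first", "only" and "open" are said of these compounds alone.

Among the compounds with values here, in a functional assay on Huh-5-2 cells (Homo sapiens) for cytotoxicity, read by microscopy (a higher number here means that more compound is tolerated, a lower number that less compound is tolerated), compound 1 `CC(=O)OC[C@H]1O[C@@H](n2c(SCc3cc4ccccc4oc3=O)nc3cncnc32)[C@H](O)[C@@H]1O` gives 8700 nM, while compound 2 `O=c1oc2ccccc2cc1CSc1nc2cncnc2n1[C@@H]1O[C@H](CO)[C@@H](O)[C@H]1O` gives 50000 nM, the higher of the two numbers so far. Compound 3 `Cc1ccc2oc(=O)c(CSc3nc4cncnc4n3[C@@H]3O[C@H](CO)[C@@H](O)[C@H]3O)cc2c1` differs from compound 2 by methyl in place of hydrogen on an aromatic carbon. Within the data shown here, the only measured step, a 5.7-fold higher number from compound 1 to compound 2 (0.76 log units; beyond the scatter), replaces acetyl with hydrogen on an oxygen on a saturated carbon, so it is a different change and offers only a loose guide. A small move towards a lower number is expected, a 1.4-fold lower number from compound 2 to compound 3 (0.15 log units; within the scatter), within the scatter. The estimate for compound 3 is 35000 nM, with an expected range from 15000 nM to 60000 nM.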

Compound 3, half-maximal cytotoxic concentration: 46000 nM
Beside the measured number, compound 3's estimate is 1.3-fold (0.12 log units) below it; the measured number falls inside the stated range.
By their numbers in this assay, from the lowest: compound 1; then compounds 3 and 2 (each within the scatter of the next).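

The earlier compounds shown here showed only a change on an oxygen on a saturated carbon, whereas this step concerns an aromatic carbon of the six-membered ring of carbon only. There, methyl in place of hydrogen gives a 1.1-fold lower number from compound 2 to compound 3 (0.04 log units; within the scatter) in this assay, so compound 2 and compound 3 cannot be told apart, and this small addition leaves cytotoxicity unchanged within the scatter. Nothing available explains this result. Still open, as far as these compounds go, is whether an amine, a carboxylic acid or a longer chain on the same carbon would also leave the number in place.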